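Swapping Methyl for Trifluoromethoxy: What Cytotoxicity to Expect

This account rests on a few compounds, and the source may have more. Where it says the series, first, only, none or still open, it means among the compounds named here.

Compound 1 `Cc1cc(NC(=O)Nc2ccc(C)c(Cl)c2)c2ccccc2n1`: in an ADME assay on HEK293 cells (Homo sapiens) for cytotoxicity, with a stated time of 72 h (on this read-out higher numbers stand for an effect only at larger amounts of compound and lower numbers for an effect already at smaller amounts), compound 1 gives > 25000 nM, which is a limit of the assay.
Compound 2 `Cc1ccc(NC(=O)Nc2cc(C)nc3ccccc23)cc1`: compound 2 gives > 25000 nM, again a limit.
Compound 3 `Cc1cc(NC(=O)Nc2cccc(C(N)=O)c2)c2ccccc2n1`: compound 3 gives > 25000 nM, also a limit.

Compound 2 thus stands at the limit of > 25000 nM in this assay, at which 3 of the 3 values shown sit; its true value is not known. Within the data shown here, the only measured step, a step that the two limits leave unreadable from compound 1 to compound 2, is hydrogen in place of chloro on an aromatic carbon, and its size cannot be read. Compound 4 `Cc1cc(NC(=O)Nc2ccc(OC(F)(F)F)cc2)c2ccccc2n1` differs from compound 2 by trifluoromethoxy in place of methyl on an aromatic carbon. Among the measured compounds shown here, no measured step bears on this change. With every value at the limit, compound 4 is expected to sit there too, so the step that the limit leaves unreadable from compound 2 to compound 4 is expected to show no readable size. Compound 4 is therefore estimated at 30000 nM, between 15000 nM and 60000 nM.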

Compound 4, half-maximal effective concentration: 14000 nM
Compound 4: the middle estimate sits 2.1-fold (0.33 log units) above what was measured, and the stated range ends above it.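

In this assay, among these compounds, trifluoromethoxy in place of methyl at this position, para to a large group, gives the only value that is a number and not a limit, with an at least 1.7-fold lower number from compound 2 to compound 4 (0.25 log units; that floor lies within the scatter). That step is only a floor, so the true step could be larger, but on its own it does not establish a real drop. Compound 1, compound 2 and compound 3 all remain at a limit: the limit of > 25000 nM in this assay, at which 3 of the 4 values shown sit.

From the compounds shown here alone, what remains open is whether this cytotoxicity is particular to trifluoromethoxy. How trifluoromethyl, methoxy or an amine would read at this same place is not shown here.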